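A few compounds are considered here, and "the series" means these few. Any claim that something is new, unique, unknown or untested is made for them only; others in the source may bear on it.

Measured so far in an assay for inhibition of 6-phosphofructo-2-kinase/fructose-2,6-bisphosphatase 3 (Homo sapiens), read by ADP-Glo, with a stated time of 2 h; on this read-out lower numbers stand for stronger inhibition and higher numbers for weaker inhibition:
- compound 1 `Cn1ccc2ccc(-c3cc(Nc4cnccc4C(=O)NCc4cncnc4)cc4nccnc34)cc21` gives 106 nM
- compound 2 `Cn1cc(CNC(=O)c2ccncc2Nc2cc(-c3ccc4ccn(C)c4c3)c3nccnc3c2)cn1` gives 159 nM
- compound 3 `CC(=O)N1CCC(NC(=O)c2ccncc2Nc2cc(-c3ccc4ccn(C)c4c3)c3nccnc3c2)CC1` gives 18 nM

Compound 3 holds the lowest number of the three. Its separation from compound 1 is a 5.9-fold lower number from compound 1 to compound 3 (0.77 log units; beyond the scatter) and from compound 2 is an 8.8-fold lower number from compound 2 to compound 3 (0.95 log units; beyond the scatter); both steps lie beyond the scatter. The step of a 1.5-fold higher number from compound 1 to compound 2 (0.18 log units; within the scatter) lies within the scatter, so the two heteroaryl-methyl amides are not distinguished.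

Compound 4 `CN1CC(NC(=O)c2ccncc2Nc2cc(-c3ccc4ccn(C)c4c3)c3nccnc3c2)CCC1=O` differs from compound 3 by 1-methyl-6-oxopiperidin-3-yl in place of 1-acetylpiperidin-4-yl on an amide-type nitrogen. For the measured compounds named here, no measured step exchanges one saturated six-membered ring for another; the two steps that bear on it only show that the 1-acetylpiperidin-4-yl amide stands well apart from the heteroaryl-methyl amides, by modest margins. A 1-methyl-6-oxopiperidin-3-yl amide keeps a saturated ring with one hetero atom and one acceptor, so the expected step of a 1.9-fold higher number from compound 3 to compound 4 (0.29 log units; within the scatter) is small, likely within the scatter, with some risk of drifting toward the numbers of compound 1 and compound 2. Compound 4 is estimated at 35 nM, with a range of 12 nM to 110 nM in this assay.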

Compound 4, half-maximal inhibitory concentration: 116 nM
For compound 4 the middle estimate is 3.3-fold (0.52 log units) below the measured one; measured number above the stated range.
By their numbers in this assay, from the lowest: compound 3; then compounds 1, 4 and 2 (each within the scatter of the next).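

In this assay, a saturated six-membered ring on the amide-type nitrogen is not enough to keep the low number of compound 3: with the counts of ring hetero atoms, donors and acceptors unchanged, 1-methyl-6-oxopiperidin-3-yl in place of 1-acetylpiperidin-4-yl gives a clear loss (a 6.4-fold higher number from compound 3 to compound 4 (0.81 log units; beyond the scatter)). Compound 4 cannot be told apart from the heteroaryl-methyl amides (a 1.4-fold lower number from compound 2 to compound 4 (0.14 log units; within the scatter); a 1.1-fold higher number from compound 1 to compound 4 (0.04 log units; within the scatter)), so among these four amides only the 1-acetylpiperidin-4-yl group stands apart. Nothing available accounts for this gap between the two rings.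

As far as these compounds go, it remains open whether the low number of compound 3 depends on the acetyl group or on the piperidin-4-yl ring that carries it. A free piperidin-4-yl amine or a 1-(methylsulfonyl)piperidin-4-yl group on the same amide-type nitrogen would bear on that question.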